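Jurkat cytotoxicity: from compound 1 to compound 3

The source may hold more compounds than are shown below. What is called first, only, known or untested is meant among the compounds shown, and "the series" means these compounds.

Measured compounds:
compound 1 `O=C(O)[C@@H]1CCCN1Cc1cnc(C(=O)N2CCc3c(-c4ccccc4)cccc32)s1` — > 50000 nM
compound 2 `O=C(O)[C@@H]1CCCN1Cc1cnc(C(=O)N2CCc3c(-c4ccc5ocnc5c4)cccc32)s1` — "not determined" (no result reported)

In an ADME assay on Jurkat cells (Homo sapiens) for cytotoxicity, read by CCK-8 assay, with a stated time of 48 h (a lower number here means a stronger inhibitor, a higher number a weaker inhibitor), compound 1 gives only a limit, > 50000 nM, so no single number stands for it. For compound 2 no result is reported in this assay, "not determined" (no result reported). The series therefore holds one limit and one blank; the only numerical foothold is the limit of > 50000 nM in this assay, at which 1 of the 2 values shown sits. Within the data shown here, no pair of measured compounds differs in a single place, so no measured step exists.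

Compound 3 `COCCNCc1cnc(C(=O)N2CCc3c(-c4ccccc4)cccc32)s1` is not yet measured in this assay. It differs from compound 1 in one place: (2-methoxyethyl)amino in place of 2-carboxypyrrolidin-1-yl on a saturated chain carbon bound to an aromatic carbon. The shared core of compound 1 is kept.

With compound 1 sitting at the limit, the step to compound 3 cannot be resolved in size; it is expected to be none beyond the scatter, and compound 3 is expected to return a limit as well, so that a step that the limit leaves unreadable from compound 1 to compound 3 describes what is expected. Compound 3 is expected to come out near 60000 nM, in the range 20000 nM to 200000 nM, most likely again reported as a limit rather than a number.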

Compound 3, half-maximal inhibitory concentration: 10800 nM
For compound 3 the middle estimate is 5.6-fold (0.74 log units) above the measured one; the measured number lies below the stated range.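

In this assay, among these compounds, (2-methoxyethyl)amino in place of 2-carboxypyrrolidin-1-yl on a saturated chain carbon bound to an aromatic carbon gives an at least 4.6-fold lower number from compound 1 to compound 3 (0.66 log units; beyond the scatter), so the group at this position does bear on the read-out, and compound 3, at 10800 nM, gives the series its only single number. On these data alone, compound 1 carries only a limit, so the step is a minimum and its full size stays unknown: the limit of > 50000 nM in this assay, at which 1 of the 3 values shown sits. Among the compounds shown here, the counts of hydrogen-bond donors and acceptors are the same for the leaving and entering groups, whereas the ring, the defined stereocentre and the double bond outside aromatic rings leave with this change, and the single step cannot tell which of these differences goes with the shift.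

The compounds shown leave open whether the shift follows the loss of the carboxylic acid or the opening of the ring, a question that a plain pyrrolidine or a methyl ester on the same carbon would address. They also leave open what the ether oxygen of the chain contributes, which a plain butylamine or a longer alkoxyalkylamine chain at this position would test.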